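Trimming the Ethylamino Chain of Compound 1

The compounds below may be only part of what the source reports. "The series", "measured", "known", "first", "only" and "open" are said of these compounds alone.

Compound 1 `CCNc1ncc(C)c(NCc2ccc(NC(=O)c3ccc(F)cc3)cc2)n1` was tested in a functional assay on HCT-116 cells (Homo sapiens) for inhibition, read by luminescence and resazurin assay, with a stated time of 3 days; on this read-out higher numbers stand for weaker inhibition and lower numbers for stronger inhibition. In this assay compound 1 gives > 20000 nM, which is a limit of the assay rather than a number; this is the limit of > 20000 nM in this assay, at which 1 of the 3 values shown sits. Two further compounds are also in hand: compound 2 `CCCNc1nc(NCc2ccc(C(=O)NCc3ccc(F)cc3)cc2)c2cc(C)ccc2n1` gives 4400 nM in this assay, and compound 3 `CCNc1nc(NCc2ccc(C(=O)N[C@H]3C[C@@H]3c3ccccc3)cc2)c2cc(C)ccc2n1` gives 1700 nM. Compound 4 `CNc1ncc(C)c(NCc2ccc(NC(=O)c3ccc(F)cc3)cc2)n1` differs from compound 1 by hydrogen in place of methyl on a saturated chain carbon bound to a nitrogen on an aromatic ring. Going by the values given here, because compound 1 stands at the limit of > 20000 nM in this assay, at which 1 of the 3 values shown sits, no measured step exists from which a direction could be read, and no movement beyond the usual scatter is expected from compound 1 to compound 4 in this assay. Compound 4 is therefore estimated at 25000 nM, within a range from 8000 nM to 80000 nM, which corresponds to an expected step that the limit leaves unreadable from compound 1 to compound 4.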

Compound 4, half-maximal inhibitory concentration: > 20000 nM
Compound 4 ended at the assay's limit; the forecaster's own chance of this, stated with the estimate: 75%; the middle value does not contradict the limit.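

In this assay compound 1 and compound 4 both stand at a limit rather than a number, so no step can be read between them. The compounds shown leave open whether ethylamino and methylamino differ at all in inhibition on this shared core.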